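The source may report more compounds than this note shows. Statements on the series, on what has been measured and on what is new or still open speak of the compounds shown alone.

Measured compounds:
compound 1 `O=C(NCc1ccc(S(=O)(=O)c2ccccc2)cc1)c1cc2cnccc2[nH]1` — 3000 nM
compound 2 `O=S(=O)(c1ccccc1)c1ccc(CNS(=O)(=O)N2Cc3ccncc3C2)cc1` — 3000 nM
compound 3 `O=C(NCc1ccc(S(=O)(=O)C2CCOCC2)cc1)N1Cc2ccncc2C1` — 206000 nM

In a physicochemical assay for solubility, in phosphate buffer, with a stated time of 24 h, at pH 7.4, tested at 100 uM (a higher number here means a more soluble compound, a lower number a less soluble compound), compound 3 gives the highest of the three numbers; compound 1 and compound 2 both sit far lower, and each gap to compound 3 is well beyond the scatter. Among the compounds with values here, none of the measured compounds differ from one another in a single place, so no measured single-change step is available for this series.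

Compound 4 `O=C(NCc1ccc(S(=O)(=O)N2CCC(N3CCCC3)CC2)cc1)N1Cc2ccncc2C1` differs from compound 3 in one place: 4-(pyrrolidin-1-yl)piperidin-1-yl in place of oxan-4-yl on a sulfonyl sulfur. Within the data shown here, no measured pair shows what such an exchange does here, so the expectation rests on compound 3 alone. A small step in this assay is expected, upward or none beyond the scatter. Compound 4 is estimated at 250000 nM, with a range from 100000 nM to 600000 nM. That estimate means an expected step of a 1.2-fold higher number from compound 3 to compound 4 (0.08 log units; within the scatter).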

Compound 4, solubility: 6200 nM
Beside the measured number, compound 4's estimate is 40-fold (1.61 log units) above it, outside the stated range (below it).
By their numbers in this assay, from the lowest: compounds 1 and 2 (each within the scatter of the next); then compound 4; then compound 3.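

In this assay, within the data shown here, the place on the sulfonyl sulfur proves sensitive: 4-(pyrrolidin-1-yl)piperidin-1-yl in place of oxan-4-yl gives a 33-fold lower number from compound 3 to compound 4 (1.52 log units; beyond the scatter) and provides the first single-place step. The hydrogen-bond donor and acceptor counts are the same for both groups, so those counts alone do not account for the step. Nothing at hand establishes a cause for it.

Still open, from the compounds shown here alone, is how a morpholin-4-yl or dimethylamino group on the sulfonyl sulfur would read in this assay and whether the pyrrolidine ring is needed for the step.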